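Swapping Vinyl for Chloromethyl on a Carbonyl Carbon

The compounds below may be only part of what the source reports. "The series", "measured", "known", "first", "only" and "open" are said of these compounds alone.

Compound 1 `COc1ccc(/C=C/C(=O)c2ccc(OC)c3c2OC(C)(C)C=C3)cc1OCCO` in a functional assay on K562 cells (Homo sapiens) for cytotoxicity, read by MTT assay (a higher number here means a weaker inhibitor, a lower number a stronger inhibitor), gives 8750 nM
Compound 2 `C=CC(=O)Oc1cc(/C=C/C(=O)c2ccc(OC)c3c2OC(C)(C)C=C3)ccc1OC` in this assay gives 300 nM

Of these two compounds, compound 2 has the lower number in this assay, at 300 nM, which makes it the stronger inhibitor of the pair. Compound 3 `COc1ccc(/C=C/C(=O)c2ccc(OC)c3c2OC(C)(C)C=C3)cc1OC(=O)CCl` has chloromethyl in place of vinyl on a carbonyl carbon. Going by the values given here, the only measured step nearby is a 29-fold lower number from compound 1 to compound 2 (1.46 log units; beyond the scatter), where vinylcarbonyl replaced 2-hydroxyethyl on an oxygen on an aromatic ring. That step exchanged the whole group on the oxygen, whereas the carbonyl stays in compound 3. Among the compounds with values here, no measured step exchanges vinyl for chloromethyl, so its size is not directly known. A small rise in the number is expected, with the estimated step being a 1.3-fold higher number from compound 2 to compound 3 (0.12 log units; within the scatter). In this assay the estimate for compound 3 is 400 nM, with an expected range from 130 nM to 1300 nM.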

Compound 3, half-maximal inhibitory concentration: 400 nM
Beside the measured number, compound 3's estimate shows no gap at the digits printed; measured number inside the range.
By their numbers in this assay, from the lowest: compounds 2 and 3 (each within the scatter of the next); then compound 1.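

In this assay the exchange of vinyl for chloromethyl on a carbonyl carbon gives a 1.3-fold higher number from compound 2 to compound 3 (0.12 log units; within the scatter) and so leaves the two compounds inseparable. The low number of compound 2 is therefore not tied to vinyl alone, since the chloromethyl version also stands well clear of the 2-hydroxyethyl compound, with a 22-fold lower number from compound 1 to compound 3 (1.34 log units; beyond the scatter) as the step on that oxygen. At this position, two different groups on the carbonyl carbon thus read alike, and both are beyond the scatter from compound 1. No evidence is available on why these two groups read alike or why compound 1 stands apart. The compounds shown leave open whether a plain methyl, a longer chain or an amine on the carbonyl carbon would read the same way. They also leave open how a carbonyl-free group such as methyl on that oxygen would compare.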